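Swapping a Nitro Group for a Methoxy Group

The source may report more compounds than this note shows. Statements on the series, on what has been measured and on what is new or still open speak of the compounds shown alone.

Of the compounds shown here, two built on one shared core have been measured in a functional assay on thoracic aorta for antagonist activity at Alpha-1D adrenergic receptor (Rattus norvegicus); a lower number here means a less potent compound, a higher number a more potent compound, by a factor of ten per unit of this negative logarithm. Compound 1 `COc1cccc(OC)c1OCCNCCOc1ccccc1OCc1ccccc1[N+](=O)[O-]` carries a 2-nitrophenyl on a saturated chain carbon bound to an oxygen on an aromatic ring, and in this assay compound 1 gives 8.95. Compound 2 `COc1cccc(OC)c1OCCNCCOc1ccccc1OCc1ccc([N+](=O)[O-])cc1` carries a 4-nitrophenyl in the same place, and compound 2 gives 9.41. Within the data shown here, the single step between them, a number 0.46 log units higher from compound 1 to compound 2 (beyond the scatter), lies beyond the usual scatter. Among the measured compounds shown here, compound 2 therefore stands highest of the two numbers measured so far, with compound 1 as its nearest neighbour.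

Compound 3 `COc1ccccc1COc1ccccc1OCCNCCOc1c(OC)cccc1OC` has not yet been measured. It differs from compound 2 in one place: 2-methoxyphenyl in place of 4-nitrophenyl on a saturated chain carbon bound to an oxygen on an aromatic ring. For the measured compounds named here, the only measured step concerns where a nitro group sits on that ring, not the exchange of a nitro group for a methoxy group, so it bears on this change only loosely. Because the step of a number 0.46 log units higher from compound 1 to compound 2 (beyond the scatter) ran upward when the nitro group was moved, a change that removes the nitro group altogether is given a modest fall, and compound 3 is expected to show the step of a number 0.41 log units lower from compound 2 to compound 3 (beyond the scatter). The estimate for compound 3 in this assay is 9, with a range from 8.3 to 9.7.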

Compound 3, negative logarithm of the antagonist equilibrium constant: 8.86
Estimate against measurement, compound 3: 0.14 log units above; the range from low to high includes it.
By their numbers in this assay, from the lowest: compounds 3 and 1 (each within the scatter of the next); then compound 2.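

In this assay the exchange of 4-nitrophenyl for 2-methoxyphenyl gives a number 0.55 log units lower from compound 2 to compound 3 (beyond the scatter) and so shows that this position responds to a change of group, but this step alters both the group and where it sits on the ring. The step that alters only the group, from 2-nitrophenyl to 2-methoxyphenyl, gives a number 0.09 log units lower from compound 1 to compound 3 (within the scatter) and shows that methoxy and nitro cannot be told apart in this assay when they sit in that same arrangement. Among these three compounds only compound 2 stands apart, and the fall from it cannot be read as a simple loss of the nitro group: compound 1 carries a nitro group too, yet lies within the scatter of compound 3.

The compounds shown leave open what a 4-methoxyphenyl would give in this place, which would help show whether the higher number of compound 2 belongs to the nitro group or to where it sits, and how an amine or a carboxylic acid on that ring would compare. Nothing measured here offers an explanation for these numbers.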